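This account rests on a few compounds, and the source may have more. Where it says the series, first, only, none or still open, it means among the compounds named here.

Values so far in an ADME assay on microsomes from liver (Homo sapiens) for metabolic stability, with a stated time of 30 min; a higher number here means that more of the compound is left, a lower number that less of the compound is left
compound 1 `COc1nc2c(cc1Nc1ccc(Cl)c(F)c1)c(=O)c(C(=O)O)cn2[C@H](CO)C(C)C` gives "not determined" (no result reported)
compound 2 `COc1nc2c(cc1NCc1ccc(F)cc1)c(=O)c(C(=O)O)cn2[C@H](CO)C(C)C` gives 87%
compound 3 `COc1nc2c(cc1NCc1ccccc1F)c(=O)c(C(=O)O)cn2[C@H](CO)C(C)C` gives 97%

Among the compounds with values here, compound 3 stands within the scatter of compound 2, the only other number available, and compound 1 offers no comparison. Compound 4 `COc1nc2c(cc1NCc1ccc(F)cc1F)c(=O)c(C(=O)O)cn2[C@H](CO)C(C)C` comes from compound 3 by a single change fluoro in place of hydrogen on an aromatic carbon and so carries a 2,4-difluorobenzyl group. The new fluoro sits para to a large group and meta to the existing fluoro group. Within the data shown here, one measured step bears on this change, a number 10 percentage points higher from compound 2 to compound 3 (within the scatter) in which 2-fluorophenyl replaces 4-fluorophenyl. Among the measured compounds shown here, compound 4 holds both of these fluoro groups, and no measured compound shows them together. No step beyond the scatter is therefore expected in this assay in either direction. The estimated shift (a number 5 percentage points lower from compound 3 to compound 4 (within the scatter)) stays small. For compound 4 the estimate is 92% with an expected range from 80% to 100% in this read-out.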

Compound 4, percent of the compound remaining: 87%
Estimate against measurement, compound 4: 5 percentage points above, and the stated range covers the measured number.
By their numbers in this assay, from the lowest: compounds 2, 4 and 3 (each within the scatter of the next).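

In this assay, the 2,4-difluorobenzyl group of compound 4 can be set against each group carrying a single fluoro group: a number 10 percentage points lower from compound 3 to compound 4 (within the scatter) and no change at the digits printed from compound 2 to compound 4 (within the scatter). Compound 4 is the only compound shown that holds both fluoro groups, and with it compounds 2, 3 and 4 cannot be told apart in this assay, so no contribution of the fluoro group para to the large group can be read from these steps. Nothing shown accounts for this result.

Still open, from the compounds shown here alone, is how a plain benzyl group, a benzyl group with an amine or a carboxylic acid in this position, or a longer chain between the nitrogen and the aromatic ring would read in this assay. Compound 1 gives "not determined" (no result reported), so no comparison with it can be read.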